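The compounds below may be only part of what the source reports. "The series", "measured", "known", "first", "only" and "open" are said of these compounds alone.

Of the compounds shown here, three have been tested in a functional assay on A549 cells (Homo sapiens) for antiproliferative activity, read by MTT assay, with a stated time of 24 h; on this read-out lower numbers stand for stronger inhibition and higher numbers for weaker inhibition. Compound 1 `Cc1ccc(-c2nn(-c3ccccc3)cc2-c2nc3ccccc3n2S(=O)(=O)c2ccc(F)cc2)cc1` gives 3240 nM, compound 2 `Cc1ccc(-c2nn(-c3ccccc3)cc2-c2nc3ccccc3n2S(=O)(=O)c2ccc(Cl)cc2)cc1` gives 3550 nM, and compound 3 `O=S(=O)(c1ccc(F)cc1)n1c(-c2cn(-c3ccccc3)nc2-c2ccc(F)cc2)nc2ccccc21` gives 2370 nM. Compound 2 differs from compound 1 in one place: chloro in place of fluoro on an aromatic carbon That change made the step of a 1.1-fold higher number from compound 1 to compound 2 (0.04 log units; within the scatter). Compound 3 differs from compound 1 in one place as well: fluoro in place of methyl on an aromatic carbon That change made the step of a 1.4-fold lower number from compound 1 to compound 3 (0.14 log units; within the scatter). Compound 4 `O=S(=O)(c1ccc(Cl)cc1)n1c(-c2cn(-c3ccccc3)nc2-c2ccc(F)cc2)nc2ccccc21` has not yet been measured. It differs from compound 3 in one place: chloro in place of fluoro on an aromatic carbon This is the same change already seen from compound 1 to compound 2, at the same place, carried over onto the core of compound 3. Because the step of a 1.1-fold higher number from compound 1 to compound 2 (0.04 log units; within the scatter) stayed within the scatter, a similarly small step is expected from compound 3 to compound 4, namely a 1.1-fold higher number from compound 3 to compound 4 (0.04 log units; within the scatter). Compound 4 is therefore estimated to give 2600 nM, with a likely range from 1300 nM to 5200 nM.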

Compound 4, half-maximal inhibitory concentration: 3170 nM
Compound 4: middle estimate off by 1.2-fold (0.09 log units), on the low side; the range from low to high includes it.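

In this assay, within the data shown here, changing (4-fluorophenyl)sulfonyl to (4-chlorophenyl)sulfonyl gave a 1.3-fold higher number from compound 3 to compound 4 (0.13 log units; within the scatter), a step much like the one seen for this change on the core of compound 1: the same change on two cores in this assay, a 1.1-fold higher number (0.04 log units; within the scatter) from compound 1 to compound 2 and a 1.3-fold higher number (0.13 log units; within the scatter) from compound 3 to compound 4, 1.2-fold (0.09 log units) apart, within the scatter of two such steps. Fluoro in place of methyl gave a 1.1-fold lower number from compound 2 to compound 4 (0.05 log units; within the scatter), which likewise matches the earlier step: the same change on two cores in this assay, a 1.4-fold lower number (0.14 log units; within the scatter) from compound 1 to compound 3 and a 1.1-fold lower number (0.05 log units; within the scatter) from compound 2 to compound 4, 1.2-fold (0.09 log units) apart, within the scatter of two such steps. Among these compounds, both changes therefore carry across these two cores without a step that stands out, but every step lies within the scatter, so this shows only that neither change moves the number measurably here, not that either has a real effect or that the pattern holds on other cores.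

The compounds shown leave open what a clearly different group, such as an amine, a carboxylic acid or a longer chain, would do at these places.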